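Compound 3 to compound 4: a carbonyl returns on oxygen

This account rests on a few compounds, and the source may have more. Where it says the series, first, only, none or still open, it means among the compounds named here.

The series varies one group on the shared core, read in a functional assay on MCF7 cells (Homo sapiens) for antiproliferative activity, read by MTT assay, with a stated time of 72 h; on this read-out higher numbers stand for weaker inhibition and lower numbers for stronger inhibition. Compound 1 (`CC1=CC[C@H]2[C@H](CC[C@]2(C)O)C(C)(C)[C@@H]1CC[C@H]1[C@]2(C)CC[C@H](OC(=O)CCC(=O)O)C(C)(C)O[C@H]2CC[C@@]1(C)O`) reads > 50000 nM, which is a limit of the assay and not a number. Going by the values given here, compound 2 (`CC1=CC[C@H]2[C@H](CC[C@]2(C)O)C(C)(C)[C@@H]1CC[C@H]1[C@]2(C)CC[C@H](OC(=O)c3ccccc3)C(C)(C)O[C@H]2CC[C@@]1(C)O`) gives 21000 nM, the only true number so far. Compound 3 (`CC1=CC[C@H]2[C@H](CC[C@]2(C)O)C(C)(C)[C@@H]1CC[C@H]1[C@]2(C)CC[C@H](OCc3ccccc3)C(C)(C)O[C@H]2CC[C@@]1(C)O`) reads > 50000 nM, again a limit and not a number, so its position is known only from one side.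

The next compound is compound 4 (`CC1=CC[C@H]2[C@H](CC[C@]2(C)O)C(C)(C)[C@@H]1CC[C@H]1[C@]2(C)CC[C@H](OC(=O)c3ccc(F)cc3)C(C)(C)O[C@H]2CC[C@@]1(C)O`), with (4-fluorophenyl)carbonyl in place of benzyl on an oxygen on a saturated carbon.

Among the compounds with values here, two measured steps bear on this change. The closer one is an at least 2.3-fold higher number from compound 2 to compound 3 (0.37 log units; beyond the scatter), with benzyl in place of benzoyl, which runs nearly opposite to the present change. The other is an at least 2.3-fold lower number from compound 1 to compound 2 (0.37 log units; beyond the scatter), which shows a difference among the acyl groups. Within the data shown here, no measured step isolates the fluorine, so the benzoyl ester compound 2 at 21000 nM serves as the anchor. A modest step towards a lower number is therefore expected. For compound 4 the expected step is an at least 2.5-fold lower number from compound 3 to compound 4 (0.39 log units; beyond the scatter). The estimated value for compound 4 is 20000 nM, with an expected range from 9000 nM to 45000 nM.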

Compound 4, half-maximal inhibitory concentration: 33500 nM
For compound 4 the middle estimate is 1.7-fold (0.22 log units) below the measured one; measured number inside the range.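

Fluoro in place of hydrogen on an aromatic carbon gives a 1.6-fold higher number from compound 2 to compound 4 (0.20 log units; within the scatter), so the two aromatic esters cannot be told apart at this position. Compound 4 also supplies the second true number on this oxygen: of the four compounds, the two with an aromatic ring directly on the carbonyl are the two that read as numbers, and none of the four goes against this. The steps to compound 4 from the other two compounds are weaker evidence, an at least 1.4-fold lower number from compound 3 to compound 4 (0.17 log units; that floor lies within the scatter) and an at least 1.4-fold lower number from compound 1 to compound 4 (0.17 log units; that floor lies within the scatter), so neither floor by itself sets compound 4 apart beyond the scatter, unlike the earlier steps involving compound 2: the limit of > 50000 nM in this assay, at which 2 of the 4 values shown sit.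

Fluoro is the only group varied on the aromatic ring, so the effect of an amine or a methoxy group on that ring remains open, as does that of a longer chain on the carbonyl carbon. The compounds also leave unresolved whether an amide in place of the ester on this oxygen would keep a readable number, and every reading shown remains weak, with no variation on the rest of the shared core.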